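A few compounds are considered here, and "the series" means these few. Any claim that something is new, unique, unknown or untested is made for them only; others in the source may bear on it.

Measured so far:
compound 1, `COc1ccc(-c2cnc(NC(=O)c3cccnc3)n2C)cc1` — > 100000 nM
compound 2, `Cn1c(-c2cccc(C#N)c2)cnc1NC(=O)c1ncc[nH]1` — > 50000 nM

Both numbers come from a toxicity assay on THP-1 cells (Homo sapiens) for inhibition; a higher number here means that more compound is tolerated, a lower number that less compound is tolerated. In this assay compound 1 gives > 100000 nM, and this is a limit of the assay, not a measured number: no toxicity was seen up to the highest concentration tested, so compound 1 sits at the limit of > 100000 nM in this assay, at which 1 of the 2 values shown sits. Compound 2 likewise reaches only a limit, > 50000 nM, as shown by the limit of > 50000 nM in this assay, at which 1 of the 2 values shown sits. Going by the values given here, neither compound therefore has a numerical value, and no step between measured compounds can be stated; the two values show only that both are tolerated at the highest levels tested.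

Compound 3, `COc1ccc(-c2cnc(NC(=O)c3cnc[nH]3)n2C)cc1`, has not been measured yet. It differs from compound 1 in one place: 1H-imidazol-5-yl in place of pyridin-3-yl on a carbonyl carbon.

Among the compounds with values here, no measured step covers this change, so any expectation rests on the two limits alone. The step of a number no higher from compound 1 to compound 3 (the limit leaves the size open) is expected to be none beyond the scatter, with compound 3 most likely again reaching only a limit. The estimate for compound 3 in this assay is 100000 nM, within a range from 50000 nM to 200000 nM.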

Compound 3, half-maximal cytotoxic concentration: > 100000 nM
Compound 3: no number, only a limit (the forecaster's own chance of this, stated with the estimate: 85%); the middle value sits exactly at the limit.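

In this assay compound 3 gives > 100000 nM, which is a limit of the assay and not a number. Going by these compounds alone, compound 1 also stands at a limit, so no step from one to the other can be read. The compounds shown leave open what concentration harms these cells, and whether 1H-imidazol-5-yl in place of pyridin-3-yl changes it.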